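The source may hold more compounds than are shown below. What is called first, only, known or untested is meant among the compounds shown, and "the series" means these compounds.

Measured in a functional assay on B16-F10 cells (Mus musculus) for antiproliferative activity, read by MTT assay, with a stated time of 48 h; a higher number here means a weaker inhibitor, a lower number a stronger inhibitor:
- Compound 1 `CC(=O)N1N=C(c2ccc3ccccc3c2)OC1c1ccccc1Cl`: 4.93 ug/mL
- Compound 2 `CC(=O)N1N=C(c2ccc3ccccc3c2)OC1c1ccccc1F`: 6.05 ug/mL
- Compound 3 `CC(=O)N1N=C(c2ccc3ccccc3c2)OC1c1ccccc1[N+](=O)[O-]`: 9.01 ug/mL

Compound 3, at 9.01 ug/mL, stands within the scatter of both other compounds, as a 1.8-fold higher number from compound 1 to compound 3 (0.26 log units; within the scatter) and a 1.5-fold higher number from compound 2 to compound 3 (0.17 log units; within the scatter) show. Compound 4 `CC(=O)N1N=C(c2ccc3ccccc3c2)OC1c1ccccn1` carries pyridin-2-yl in place of 2-nitrophenyl on a saturated ring carbon. The nearest evidence is these two steps together with a 1.2-fold higher number from compound 1 to compound 2 (0.09 log units; within the scatter), all of them small. Going by the values given here, none of them replaces the aromatic ring itself, so the data hold no direct precedent. In this assay, going by these compounds, no step beyond the scatter is expected, and the direction stays open. The expected step is a 1.2-fold lower number from compound 3 to compound 4 (0.08 log units; within the scatter). Compound 4 is estimated at 7.5 ug/mL, with an expected range of 3.5 ug/mL to 16 ug/mL.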

Compound 4, half-maximal inhibitory concentration: 7.18 ug/mL
Compound 4: middle estimate off by 1.0-fold (0.02 log units), on the high side; the measured number falls inside the stated range.
By their numbers in this assay, from the lowest: compounds 1, 2, 4 and 3 (each within the scatter of the next).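

In this assay, going by these compounds alone, the aromatic ring itself on this saturated ring carbon is now replaced for the first time, and pyridin-2-yl stays within the scatter of all three substituted phenyl groups: a 1.3-fold lower number from compound 3 to compound 4 (0.10 log units; within the scatter), a 1.2-fold higher number from compound 2 to compound 4 (0.07 log units; within the scatter) and a 1.5-fold higher number from compound 1 to compound 4 (0.16 log units; within the scatter). Thus the tolerance seen earlier among chloro, fluoro and nitro extends to a ring with one hetero atom and no such substituent. Nothing measured here explains this result. The compounds shown leave open whether pyridin-3-yl, or an amine or carboxylic acid on the ring at this carbon, would produce a step beyond the scatter.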